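Trifluoromethylphenyl for methylphenyl on a shared core

The source may report more compounds than this note shows. Statements on the series, on what has been measured and on what is new or still open speak of the compounds shown alone.

Compound 1 `Cc1cccc(-c2nn(-c3ccc(F)cc3F)cc2CNCCN2CCN(C)CC2)c1` is the starting point of this step. In an ADME assay on Huh-7 cells (Homo sapiens) for cytotoxicity (a lower number here means that less compound is tolerated, a higher number that more compound is tolerated), compound 1 gives > 20000 nM, which is a limit of the assay and not a number. Compound 1 thus sits at the limit of > 20000 nM in this assay, at which 1 of the 2 values shown sits, so its true position can only be placed at or beyond that edge. Compound 2 `CCCN1CCC(CNCc2cn(-c3ccc([N+](=O)[O-])cc3)nc2-c2ccc(C(F)(F)F)cc2)CC1` is another member of the set; in this assay compound 2 gives 2300 nM. Among the measured compounds shown here, no single-point step connects compound 2 to compound 1, so the two values stand only side by side. Compound 3 `CN1CCN(CCNCc2cn(-c3ccc(F)cc3F)nc2-c2ccc(C(F)(F)F)cc2)CC1` has not yet been measured. It differs from compound 1 in one place: 4-(trifluoromethyl)phenyl in place of 3-methylphenyl on an aromatic carbon. For the measured compounds named here, with no measured step of this kind to lean on, a modest move toward less tolerance is expected, an at least 1.6-fold lower number from compound 1 to compound 3 (0.22 log units; that floor lies within the scatter), though such a move may also stay within the scatter. Compound 3 is therefore expected to give about 12000 nM in this assay, with a likely range from 4000 nM to 40000 nM.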

Compound 3, half-maximal cytotoxic concentration: 20000 nM
For compound 3 the middle estimate is 1.7-fold (0.22 log units) below the measured one, and the stated range covers the measured number.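

With this pair, the aromatic carbon of the five-membered ring gets its first change in one place, and in this assay compound 3, which carries 4-(trifluoromethyl)phenyl, gives 20000 nM. Compound 1 gives > 20000 nM, which is a limit of the assay and not a number. Putting 4-(trifluoromethyl)phenyl in place of 3-methylphenyl gives a number no higher from compound 1 to compound 3 (the limit leaves the size open), and the size of the step stays unknown because compound 1 stands at the edge of what the assay reports: the limit of > 20000 nM in this assay, at which 1 of the 3 values shown sits.

What a 4-chlorophenyl or an unsubstituted phenyl would give at this place remains open, so the shown pair cannot separate the trifluoromethyl group from the change of the group's position on the phenyl ring. Also open, on these data alone, is how an amine or a carboxylic acid on that phenyl ring would read in this assay.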